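Removing the chloro from the aryl group of compound 2

The source may report more compounds than this note shows. Statements on the series, on what has been measured and on what is new or still open speak of the compounds shown alone.

Compound 2 `CCC1(CCCCN2CCN(c3ccccc3Cl)CC2)C(=O)Nc2ccccc21` and compound 1 `CCC1(CCCCN2CCN(c3ccc(F)cc3)CC2)C(=O)Nc2ccccc21` share one core and differ only in the aryl group on an amine nitrogen in a ring. In a functional assay on the whole organism (strain Wistar) with Rattus norvegicus as the target, with a stated time of 5 min (a lower number here means that less compound is needed, a higher number that more compound is needed for the effect), compound 2 gives > 20 mg/kg, which is a limit of the assay and not a number. In this assay compound 1 gives 10 mg/kg. For the measured compounds named here, the single measured step is an at least 2.0-fold higher number from compound 1 to compound 2 (0.30 log units; that floor lies within the scatter), and its true size stays open because only the limit of > 20 mg/kg in this assay, at which 1 of the 2 values shown sits, is known for compound 2. Compound 3 `CCC1(CCCCN2CCN(c3ccccc3)CC2)C(=O)Nc2ccccc21` is not yet measured; it differs from compound 2 by hydrogen in place of chloro on an aromatic carbon. This removes the chloro that separates compound 2 from compound 1, so the phenyl of compound 3 stands nearer to the 4-fluorophenyl of compound 1 than to the 2-chlorophenyl of compound 2. The number for compound 3 is therefore expected to fall, an at least 1.3-fold lower number from compound 2 to compound 3 (0.12 log units; that floor lies within the scatter), though a result at the limit again is possible. Compound 3 is estimated at 15 mg/kg, with a range from 5 mg/kg to 40 mg/kg.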

Compound 3, minimum effective dose: 10 mg/kg
Compound 3: the middle estimate sits 1.5-fold (0.18 log units) above what was measured, and the stated range covers the measured number.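

Taking the chloro off the aromatic carbon turns a result at the limit into a readable number in this assay, with an at least 2.0-fold lower number from compound 2 to compound 3 (0.30 log units; that floor lies within the scatter). From the compounds shown here alone, compound 2 stands at a limit of the assay and not at a number, so the true size of that step stays open: the limit of > 20 mg/kg in this assay, at which 1 of the 3 values shown sits. Hydrogen in place of the fluoro gives no change at the digits printed from compound 1 to compound 3 (within the scatter), so the 4-fluorophenyl and the plain phenyl cannot be told apart here, and the fluoro is not needed for a readable number.

Open, going by these compounds, is whether the gap to the 2-chlorophenyl follows the chlorine itself or its place on the ring, which a 4-chlorophenyl or a 2-fluorophenyl would separate. Also open, on these data alone, is whether a 2-methoxyphenyl at the same carbon would read like the phenyl or stay at the limit.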